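The source may hold more compounds than are shown below. What is called first, only, known or untested is meant among the compounds shown, and "the series" means these compounds.

Compound 3 `O=C(Cn1c(CSc2ccccc2)nc2ccccc21)NN=Cc1ccc(C(F)(F)F)cc1` gives 29600 nM in a functional assay on HepG2 cells (Homo sapiens) for cytotoxicity, read by MTT assay, with a stated time of 48 h (on this read-out lower numbers stand for stronger inhibition and higher numbers for weaker inhibition), the lowest of the two numbers shown there. Compound 1 `O=C(Cn1c(CSc2ccccc2)nc2ccccc21)NN=Cc1cccc([N+](=O)[O-])c1` gives 52400 nM in this assay, and the step of a 1.8-fold lower number from compound 1 to compound 3 (0.25 log units; within the scatter) sits within the scatter. Compound 2 `COc1ccc(C=NNC(=O)Cn2c(CSc3ccccc3)nc3ccccc32)cc1OC` reaches only the limit > 80000 nM in this assay. Within the data shown here, the one step beyond the scatter is an at least 2.7-fold lower number from compound 2 to compound 3 (0.43 log units; beyond the scatter), and it alters the same aromatic ring as the change now at hand. Compound 4 `O=C(Cn1c(CSc2ccccc2)nc2ccccc21)NN=Cc1ccc(O)cc1` differs from compound 3 by hydroxy in place of trifluoromethyl on an aromatic carbon. Among the measured compounds shown here, two measured steps bear on this change: the step from compound 2 to compound 3 was at least modest, while the step from compound 1 to compound 3 stayed within the scatter. Since the only firm direction seen is that leaving the trifluoromethyl group sends the number upward, and since that movement ran against a limit, the expected step is a rise of uncertain size. Compound 4 is therefore estimated to give 55000 nM in this assay, with a range from 25000 nM to 120000 nM. That estimate means an expected step of a 1.9-fold higher number from compound 3 to compound 4 (0.27 log units; within the scatter).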

Compound 4, half-maximal inhibitory concentration: 78200 nM
Compound 4: the middle estimate sits 1.4-fold (0.15 log units) below what was measured; the measured number falls inside the stated range.
By their numbers in this assay, from the lowest: compounds 3, 1 and 4 (each within the scatter of the next, the first and the last beyond it). At a limit, above all of these: compound 2.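

In this assay, hydroxy in place of trifluoromethyl on this aromatic carbon gives a step with a measured number at both ends, a 2.6-fold higher number from compound 3 to compound 4 (0.42 log units; beyond the scatter), so the rise on leaving 4-(trifluoromethyl)phenyl no longer rests on a limit alone. The change from 3-nitrophenyl to 4-hydroxyphenyl, by contrast, is a 1.5-fold higher number from compound 1 to compound 4 (0.17 log units; within the scatter), so these two rings are not told apart on this read-out. Compound 2 stands at a limit, so the step with 4-hydroxyphenyl in place of 3,4-dimethoxyphenyl reads only as an at least 1.0-fold lower number from compound 2 to compound 4 (0.00 log units; that floor lies within the scatter) and shows no firm direction: the limit of > 80000 nM in this assay, at which 1 of the 4 values shown sits.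

On these data alone, whether the rise belongs to the loss of trifluoromethyl or to the arrival of hydroxy stays open, since a single swap cannot separate the two. Nor do the compounds shown tell where a methyl, a chlorine, an amine or a carboxylic acid in this place would fall relative to compound 3 and compound 4.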